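The source may hold more compounds than are shown below. What is called first, only, known or untested is meant among the compounds shown, and "the series" means these compounds.

Measured in a functional assay on B16-F10 cells (Mus musculus) for antiproliferative activity, read by MTT assay, with a stated time of 48 h; a higher number here means a weaker inhibitor, a lower number a stronger inhibitor:
- Compound 1 `CC(=O)N1N=C(c2ccc3ccccc3c2)OC1c1ccccc1Cl`: 4.93 ug/mL
- Compound 2 `CC(=O)N1N=C(c2ccc3ccccc3c2)OC1c1ccc(F)cc1`: 4.65 ug/mL
- Compound 3 `CC(=O)N1N=C(c2ccc3ccccc3c2)OC1c1ccccc1[N+](=O)[O-]`: 9.01 ug/mL

Compound 3 stands within the scatter of both other compounds, as a 1.8-fold higher number from compound 1 to compound 3 (0.26 log units; within the scatter) and a 1.9-fold higher number from compound 2 to compound 3 (0.29 log units; within the scatter) show. Compound 4 `CC(=O)N1N=C(c2ccc3ccccc3c2)OC1c1ccccc1O` keeps the shared core and carries hydroxy in place of nitro on an aromatic carbon.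

Among the measured compounds shown here, no measured compound carries hydroxy, so the data offer only indirect guidance. For the measured compounds named here, the closest evidence is the first of those two steps, which exchanges chloro and nitro on an aromatic carbon. The step of a 1.1-fold lower number from compound 1 to compound 2 (0.03 log units; within the scatter) adds a further change of aryl group that also stays within the scatter. All three steps are small, so no step beyond the scatter is expected in this assay, and any drift would be expected towards lower numbers. The expected step is a 1.5-fold lower number from compound 3 to compound 4 (0.18 log units; within the scatter). For compound 4 the estimated value is 6 ug/mL, with an expected range of 2.5 ug/mL to 14 ug/mL.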

Compound 4, half-maximal inhibitory concentration: 2.58 ug/mL
Estimate against measurement, compound 4: 2.3-fold (0.37 log units) above; measured number inside the range.
By their numbers in this assay, from the lowest: compounds 4, 2, 1 and 3 (each within the scatter of the next, the first and the last beyond it).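

In this assay, the exchange of nitro for hydroxy on an aromatic carbon ortho to a large group gives a 3.5-fold lower number from compound 3 to compound 4 (0.54 log units; beyond the scatter) as the only step beyond the scatter among those shown, whereas all the earlier steps stayed within it. The other two new steps, a 1.8-fold lower number from compound 2 to compound 4 (0.26 log units; within the scatter) and a 1.9-fold lower number from compound 1 to compound 4 (0.28 log units; within the scatter), stay within the scatter, so hydroxy is set apart from nitro but not from chloro at this place or from the 4-fluorophenyl group. No measurement among those shown explains the step from nitro to hydroxy.

The compounds shown leave open whether an amine or a methoxy group at this place would read with hydroxy or with nitro. They also leave open whether the same exchange elsewhere on this ring would give a step of similar size.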